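The source may hold more compounds than are shown below. What is called first, only, known or untested is meant among the compounds shown, and "the series" means these compounds.

Measured compounds and values:
- compound 1, `OC[C@H]1O[C@H](Oc2ccc(-c3ccc(Cl)cc3Cl)cc2Cl)[C@@H](O)[C@@H](O)[C@@H]1O`: "not determined" (no result reported)
- compound 2, `N#Cc1cccc(-c2ccc(O[C@H]3O[C@H](CO)[C@@H](O)[C@H](O)[C@@H]3O)c(Cl)c2)c1`: 2.1

Compound 1 carries a 2,4-dichlorophenyl group on the shared core. Within the data shown here, in a physicochemical assay for lipophilicity, read by LC-MS, measured as octanol-water partition, with a stated time of 2 h, at pH 7.4, tested at 1 uM (a lower number here means a more polar compound, a higher number a more lipophilic compound), compound 1 has no single number, so it cannot be placed on the scale; compound 2, the only measured member of the pair, gives 2.1 in this assay and serves as the sole anchor. Among the measured compounds shown here, no step between two measured compounds exists in this set.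

Compound 3, `OC[C@H]1O[C@H](Oc2ccc(-c3ccccc3)cc2Cl)[C@@H](O)[C@@H](O)[C@@H]1O`, is not yet measured. Its change from compound 1 is phenyl in place of 2,4-dichlorophenyl on an aromatic carbon. With compound 1 unmeasured, no direction or size can be read for this step from the data; any expectation rests on compound 2 alone. Compound 3 shares the core and the chloro group with compound 2 and differs from it by lacking the nitrile, which in this set gives no measured guide. Compound 3 is expected to land in this assay near 2.5, within roughly 2 to 3.1, with the anchor being compound 2 at 2.1.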

Compound 3, distribution coefficient: 2.6
Compound 3: middle estimate off by 0.10 log units, on the low side; the measured number falls inside the stated range.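

In this assay the series now has its first readable step: hydrogen in place of cyano on an aromatic carbon gives a number 0.50 log units higher from compound 2 to compound 3 (beyond the scatter) and so shows that a single change on this outer aromatic ring can move the read-out by more than the usual scatter. Compound 3 thus gives the scale a second measured point on the shared core, with an unsubstituted phenyl as the reference for this ring, while the step from compound 1 to compound 3 still cannot be read, so the replacement of 2,4-dichlorophenyl by phenyl has no direction or size. No measurement in hand accounts for the direction or size of the step from cyano to hydrogen.

Going by these compounds, it remains open where the 2,4-dichlorophenyl group of compound 1 falls on this scale relative to the phenyl of compound 3 and whether each chloro group on that ring contributes to any difference. On these data alone, it is also open how an amine, a carboxylic acid or a methoxy group on that aromatic ring would compare with hydrogen and cyano in this assay, and whether a single step from one pair holds for other groups.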